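Fluoro in place of hydrogen: compound 2 to compound 3

The compounds below may be only part of what the source reports. "The series", "measured", "known", "first", "only" and "open" are said of these compounds alone.

Of the compounds shown here, two have numbers so far. In a functional assay on T98G cells (Homo sapiens) for cytotoxicity, read by MTT assay, with a stated time of 48 h (a lower number here means a stronger inhibitor, a higher number a weaker inhibitor), compound 1 (`C/C(=N\NC(=S)Nc1ccc(Cl)cc1)c1ccccn1`) gives 5.9 nM and compound 2 (`C/C(=N\NC(=S)Nc1ccccc1)c1ccccn1`) gives 6.81 nM, which places compound 2 within the scatter of compound 1. Compound 3 (`C/C(=N\NC(=S)Nc1ccc(F)cc1)c1ccccn1`) has not yet been measured. Its difference from compound 2 is fluoro in place of hydrogen on an aromatic carbon, para to a large group. Among the measured compounds shown here, the one measured step at that place is a 1.2-fold higher number from compound 1 to compound 2 (0.06 log units; within the scatter), with hydrogen in place of chloro. This single step involves chloro rather than fluoro, so it is limited evidence. Nothing beyond the scatter is therefore expected in this assay, and no direction is favoured. The expected step is a 1.1-fold lower number from compound 2 to compound 3 (0.03 log units; within the scatter). Compound 3 is estimated at 6.3 nM, with an expected range of 3 nM to 13 nM.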

Compound 3, half-maximal inhibitory concentration: 17 nM
The estimate for compound 3 lay 2.7-fold (0.43 log units) below the measured number, and the stated range ends below it.
By their numbers in this assay, from the lowest: compounds 1 and 2 (each within the scatter of the next); then compound 3.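

In this assay, the aromatic carbon para to a large group proves sensitive to the choice of substituent: fluoro in place of hydrogen gives a 2.5-fold higher number from compound 2 to compound 3 (0.40 log units; beyond the scatter), whereas hydrogen in place of chloro gave only a 1.2-fold higher number from compound 1 to compound 2 (0.06 log units; within the scatter). Fluoro in place of chloro gives a 2.9-fold higher number from compound 1 to compound 3 (0.46 log units; beyond the scatter), so among these three compounds the order does not run from hydrogen through fluoro to chloro: compound 3 stands apart, while compounds 1 and 2 lie within the scatter of each other. No measurement at hand bears on why fluoro behaves differently from chloro at this place.

The compounds shown leave open whether the higher number is peculiar to fluoro or would also appear with bromo, methoxy or an amine at this place. They also leave open whether the same step would hold with fluoro on another carbon of that ring.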